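Chloro in place of ethynyl: notes on the series

A few compounds are considered here, and "the series" means these few. Any claim that something is new, unique, unknown or untested is made for them only; others in the source may bear on it.

The compounds here share one core and are followed in a functional assay on BMDM cells (Mus musculus, strain C57BL/6) for inhibition, with a stated time of 2 days; a higher number here means a weaker inhibitor, a lower number a stronger inhibitor. Compound 1 `O=C(Cn1cc(-c2ccccc2Cl)nn1)Nc1nccs1` gives 60 nM. Compound 2 `Cc1cc(NC(=O)Cn2cc(-c3ccc(Cl)cc3)nn2)no1` gives 1910 nM in this assay, a weaker value than that of compound 1; the two differ in more than one place, so the numbers are set side by side without further reading. Compound 3 `C#Cc1ccc(-c2cn(CC(=O)Nc3nccs3)nn2)cc1` returns only a limit in this assay, > 30000 nM, which is the ceiling at which one of the three values sits (the limit of > 30000 nM in this assay, at which 1 of the 3 values shown sits); no number is known for compound 3 beyond that limit.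

Compound 4 `O=C(Cn1cc(-c2ccc(Cl)cc2)nn1)Nc1nccs1` has not been measured. It differs from compound 3 in one place: chloro in place of ethynyl on an aromatic carbon. Among the compounds with values here, no measured pair in the set differs in this one place, so the size of the step is an expectation, not a reading. For the step from compound 3 to compound 4 a gain in potency of about an at least 12-fold lower number from compound 3 to compound 4 (1.07 log units; beyond the scatter) is expected, beyond the scatter; the expectation rests on compound 2, which also carries a chloro on its aromatic ring and gives 1910 nM, and on compound 1, which also carries a chloro and gives 60 nM. Compound 4 is expected to give about 2500 nM in this assay, within 300 nM to 20000 nM.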

Compound 4, half-maximal inhibitory concentration: 1100 nM
The estimate for compound 4 lay 2.3-fold (0.36 log units) above the measured number, and the stated range covers the measured number.
By their numbers in this assay, from the lowest: compound 1; then compounds 4 and 2 (each within the scatter of the next). At a limit, above all of these: compound 3.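

At this place on the ring, para to a large group, the series now has its first reading of a single-group change, and it is a large one: an at least 27-fold lower number from compound 3 to compound 4 (1.43 log units; beyond the scatter) in this assay. Compound 3 stands only at a limit of this assay, so this step has a floor and not a full size: the limit of > 30000 nM in this assay, at which 1 of the 4 values shown sits. Where the chloro sits also matters on the shared core, with 4-chlorophenyl in place of 2-chlorophenyl giving an 18-fold higher number from compound 1 to compound 4 (1.26 log units; beyond the scatter), while exchanging the group on the amide nitrogen, 1,3-thiazol-2-yl in place of 5-methyl-1,2-oxazol-3-yl, gives a 1.7-fold lower number from compound 2 to compound 4 (0.24 log units; within the scatter), a difference within the scatter.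

As far as these compounds go, whether a methoxy group or an amine at the para place would read nearer to compound 4 or nearer to compound 3 remains open, and so does how much of the step belongs to the arrival of chloro and how much to the departure of ethynyl. Also open, from the compounds shown here alone, is whether the cost of moving the chloro to the para place would hold with 5-methyl-1,2-oxazol-3-yl on the amide nitrogen.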